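From Cycloheptenyl to Tolyl on the Shared Core

This account rests on a few compounds, and the source may have more. Where it says the series, first, only, none or still open, it means among the compounds named here.

Among the compounds with values here, compound 2 `CC(C)C[C@H](N)CN(C(=O)[C@@H]1C[C@H]1c1ccccc1)c1ccc(C2=CCCCCC2)cc1` stands at the lower end of the two numbers measured so far in a functional assay for agonist activity at G protein-coupled receptor 88 (Homo sapiens), read by HTRF and cAMP accumulation (a lower number here means that less compound is needed, a higher number that more compound is needed for the effect), where compound 2 gives 2100 nM. Within the data shown here, its only neighbour, compound 1 `CC(C)C[C@H](N)CN(C(=O)[C@@H]1C[C@H]1c1ccccc1)c1ccc(-c2cccnc2)cc1`, gives 10000 nM in this assay. A single measured step connects the two: a 4.8-fold lower number from compound 1 to compound 2 (0.68 log units; beyond the scatter), a change on an aromatic carbon of the shared core. Compound 3 `Cc1ccc(-c2ccc(N(C[C@@H](N)CC(C)C)C(=O)[C@@H]3C[C@H]3c3ccccc3)cc2)cc1` has not yet been measured. It differs from compound 2 in one place: 4-methylphenyl in place of cyclohept-1-en-1-yl on an aromatic carbon. Among the measured compounds shown here, the only step that bears on this change is the one from compound 1 to compound 2, and it concerns a different pair of groups, pyridin-3-yl against cyclohept-1-en-1-yl; no measured pair involves a 4-methylphenyl. Both the group that leaves and the group that enters are rings of carbon only, so no step beyond the scatter is expected in this assay, though the direction is open. Compound 3 is therefore expected to give about 2500 nM in this assay, within a range from 800 nM to 8000 nM. The expected step is a 1.2-fold higher number from compound 2 to compound 3 (0.08 log units; within the scatter).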

Compound 3, half-maximal effective concentration: 360 nM
The estimate for compound 3 lay 6.9-fold (0.84 log units) above the measured number; measured number outside the range, below it.
By their numbers in this assay, from the lowest: compound 3; then compound 2; then compound 1.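

The change shows that, at this aromatic carbon para to a large group, the count of atoms does not settle the number: cyclohept-1-en-1-yl and 4-methylphenyl both have 7 heavy atoms, all carbon, with no hydrogen-bond donors or acceptors and no net charge, yet this assay gives a 5.8-fold lower number from compound 2 to compound 3 (0.77 log units; beyond the scatter). Taken with the earlier step, the position now spans a wider range, with a 28-fold lower number from compound 1 to compound 3 (1.44 log units; beyond the scatter), and having a six-membered aromatic ring here does not by itself give a low number, since pyridin-3-yl in compound 1 and 4-methylphenyl in compound 3 stand at the two ends of the three values. No independent measurement accompanies these numbers that would account for their order.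

The compounds shown leave open what the methyl group of 4-methylphenyl contributes, and whether a plain phenyl, a 4-chlorophenyl or a 4-ethylphenyl would give a number near that of compound 3. They also leave open whether a methyl group added to the pyridin-3-yl ring would move the number of compound 1 in the same direction.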